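This account rests on a few compounds, and the source may have more. Where it says the series, first, only, none or still open, it means among the compounds named here.

Measured in an ADME assay on BaF3 cells (Mus musculus) for cytotoxicity, read by CellTiter-Glo and CCK-8 assay, with a stated time of 72 h; a lower number here means a stronger inhibitor of growth, a higher number a weaker inhibitor of growth:
compound 1 `CCC(=O)NCc1ccc(C(=O)Nc2ccc(C)c(Nc3nccc(-c4cccnc4)n3)c2)cc1`: > 10000 nM, a limit
compound 2 `C=CC(=O)NCc1ccc(C(=O)Nc2ccc(C)c(Nc3nccc(-c4cccnc4)n3)c2)cc1`: > 10000 nM, a limit

Compound 2 therefore stands at a limit and has no number. Compound 3 `C=CS(=O)(=O)NCc1ccc(C(=O)Nc2ccc(C)c(Nc3nccc(-c4cccnc4)n3)c2)cc1` carries vinylsulfonyl in place of vinylcarbonyl on an amine nitrogen. Within the data shown here, the only measured step that bears on this, vinyl in place of ethyl on a carbonyl carbon, is a step that the two limits leave unreadable from compound 1 to compound 2, and its size cannot be read. Both values shown are limits: the limit of > 10000 nM in this assay, at which 2 of the 2 values shown sit. In this assay the expected change is therefore none beyond the scatter, an estimated a number no higher from compound 2 to compound 3 (the limit leaves the size open). The estimated value for compound 3 is 10000 nM, expected within 4000 nM to 25000 nM.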

Compound 3, concentration for 50% growth inhibition: 7710 nM
For compound 3 the middle estimate is 1.3-fold (0.11 log units) above the measured one; the range from low to high includes it.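

In this assay, among these compounds, compound 3 is the only one of the three compounds to give a number rather than a limit, so vinylsulfonyl on this amine nitrogen brings the growth inhibition into readable range. Vinylsulfonyl in place of vinylcarbonyl gives an at least 1.2-fold lower number from compound 2 to compound 3 (0.11 log units; that floor lies within the scatter), and in place of propanoyl it gives an at least 1.2-fold lower number from compound 1 to compound 3 (0.11 log units; that floor lies within the scatter); both are floors, and their true sizes stay open. The other two values remain limits: the limit of > 10000 nM in this assay, at which 2 of the 3 values shown sit.

Open, from the compounds shown here alone, is whether ethylsulfonyl on this nitrogen would give a number like that of compound 3, which would show whether the sulfonyl or the vinyl matters.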